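This account rests on a few compounds, and the source may have more. Where it says the series, first, only, none or still open, it means among the compounds named here.

Compound 3 `O=C(Nc1cccnc1)c1ccccc1OCc1cc(F)ccc1Cl` gives the lowest number of the three compounds measured in an assay on lysate for inhibition of phosphatidylcholine:ceramide cholinephosphotransferase 2 (Homo sapiens), read by HPLC, with stated times of 30 min and 2 h (on this read-out lower numbers stand for stronger inhibition and higher numbers for weaker inhibition), at 740 nM. Compound 1 `Cc1ccccc1COc1ccccc1C(=O)Nc1cccnc1` gives 1500 nM in this assay, and compound 2 `N#Cc1ccccc1COc1ccccc1C(=O)Nc1cccnc1` gives 31800 nM. Compound 4 `Cc1ccc(F)cc1COc1ccccc1C(=O)Nc1cccnc1` differs from compound 3 by methyl in place of chloro on an aromatic carbon. Among the compounds with values here, no measured step exchanges exactly these two groups. The nearest is a 2.0-fold lower number from compound 1 to compound 3 (0.31 log units; beyond the scatter), which combines the reverse of this exchange with an added fluoro group; a 21-fold higher number from compound 1 to compound 2 (1.33 log units; beyond the scatter) and a 43-fold lower number from compound 2 to compound 3 (1.63 log units; beyond the scatter) both involve a cyano group and bear less directly. A modest step in the opposite direction, or none beyond the scatter, is therefore expected, with compound 4 estimated at 1100 nM, between 450 nM and 2700 nM. The expected step is a 1.5-fold higher number from compound 3 to compound 4 (0.17 log units; within the scatter).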

Compound 4, half-maximal inhibitory concentration: 740 nM
The estimate for compound 4 lay 1.5-fold (0.17 log units) above the measured number; the range from low to high includes it.
By their numbers in this assay, from the lowest: compounds 3 and 4 (each within the scatter of the next); then compound 1; then compound 2.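

In this assay, methyl and chloro on this aromatic carbon, ortho to a large group and para to a fluoro group, cannot be told apart: the result is no change at the digits printed from compound 3 to compound 4 (within the scatter). Fluoro in place of hydrogen alone gives a 2.0-fold lower number from compound 1 to compound 4 (0.31 log units; beyond the scatter), the same size as the earlier step that combined both exchanges. Against 2-cyanophenyl, 5-fluoro-2-methylphenyl gives a 43-fold lower number from compound 2 to compound 4 (1.63 log units; beyond the scatter).

No supporting evidence accounts for these steps. From the compounds shown here alone, whether a methoxy group or a bromo group on this carbon would give a similar number remains open.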